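Adding a Hydroxy Group: Expected Tolerance in Cell Culture

The source may report more compounds than this note shows. Statements on the series, on what has been measured and on what is new or still open speak of the compounds shown alone.

Compound 2 `Cc1cc(-c2ccccc2)cn2c(CSCCc3ccccc3)cnc12` is the starting point of this step. In an ADME assay on HEL cells (Homo sapiens) for cytotoxicity, with a stated time of 3 days (a higher number here means that more compound is tolerated, a lower number that less compound is tolerated), compound 2 gives 31 ug/mL, the lowest of the two numbers recorded, although its nearest neighbour, compound 3 `Cc1cc(-c2cccc([N+](=O)[O-])c2)cn2c(CSCCc3ccccc3)cnc12`, sits close: compound 3 gives 43 ug/mL. Compound 1 `Cc1cc(-c2ccsc2)c2ncc(CSCCc3ccccc3)n2c1` reaches only > 50 ug/mL, which is a limit of the assay and not a number (the limit of > 50 ug/mL in this assay, at which 1 of the 3 values shown sits).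

Within the data shown here, the one measured step that involves compound 2 exchanges a hydrogen on an aromatic carbon for a nitro group, and it reads a 1.4-fold higher number from compound 2 to compound 3 (0.14 log units; within the scatter). Compound 4 `Cc1cc(-c2ccccc2O)cn2c(CSCCc3ccccc3)cnc12` differs from compound 2 by hydroxy in place of hydrogen on an aromatic carbon, a different group at a different place on the same phenyl ring, so the nitro step is only a loose guide. Since that single step stayed within the scatter, the step expected for this assay is a 1.0-fold higher number from compound 2 to compound 4 (0.01 log units; within the scatter), with no direction beyond the scatter. Compound 4 is therefore estimated at 32 ug/mL, within a range from 16 ug/mL to 60 ug/mL.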

Compound 4, half-maximal cytotoxic concentration: > 50 ug/mL
Compound 4 was reported as a limit (the forecaster's own chance of this, stated with the estimate: 25%); at least 1.5-fold (0.19 log units) between middle value and limit.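

In this assay the value of compound 4, > 50 ug/mL, is a limit and not a number. Hydroxy ortho to a large group therefore reads as an at least 1.6-fold higher number from compound 2 to compound 4 (0.20 log units; that floor lies within the scatter), and 2-hydroxyphenyl in place of 3-nitrophenyl reads as an at least 1.1-fold higher number from compound 3 to compound 4 (0.06 log units; that floor lies within the scatter). Unlike the nitro step, these steps have only a floor and no upper end, so they show that a hydroxy group at this place brings no visible loss of tolerance, while the true size of the change stays out of reach: the limit of > 50 ug/mL in this assay, at which 2 of the 4 values shown sit.

Going by these compounds, how far compound 4 really lies from compound 2 remains open. On these data alone, whether a methoxy group or an amine at the same place would read alike, and whether a hydroxy group elsewhere on the phenyl ring would do so, also remains open.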